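The source may hold more compounds than are shown below. What is called first, only, known or untested is meant among the compounds shown, and "the series" means these compounds.

Measured compounds in an ADME assay on NIH3T3 cells (Mus musculus) for cytotoxicity, read by MTT assay; a higher number here means a weaker inhibitor, a lower number a stronger inhibitor:
Compound 1, `N#Cc1c(-c2ccccc2)c(C#N)c(=O)n(/N=C/c2cn(-c3ccccc3)nc2-c2ccccc2)c1N`, gives 180 ug/mL.
Compound 2, `N#Cc1c(-c2ccccc2Cl)c(C#N)c(=O)n(/N=C/c2cn(-c3ccccc3)nc2-c2ccccc2)c1N`, gives 84 ug/mL.
Compound 3, `N#Cc1c(-c2ccccc2[N+](=O)[O-])c(C#N)c(=O)n(/N=C/c2cn(-c3ccccc3)nc2-c2ccccc2)c1N`, gives only a limit of the assay, > 200 ug/mL.

Compound 3 thus stands at the upper edge of what this assay reports, with no exact number; the step of an at least 1.1-fold higher number from compound 1 to compound 3 (0.04 log units; that floor lies within the scatter), and the step of an at least 2.3-fold higher number from compound 2 to compound 3 (0.37 log units; beyond the scatter), are therefore floors rather than measured sizes. The next compound, compound 4, `N#Cc1c(-c2ccc([N+](=O)[O-])cc2)c(C#N)c(=O)n(/N=C/c2cn(-c3ccccc3)nc2-c2ccccc2)c1N`, keeps the same atoms and changes only where the nitro group sits: 4-nitrophenyl in place of 2-nitrophenyl on an aromatic carbon. Among the compounds with values here, none of the measured steps moves a group from one place to another; the steps of a 2.1-fold lower number from compound 1 to compound 2 (0.33 log units; beyond the scatter) and an at least 2.3-fold higher number from compound 2 to compound 3 (0.37 log units; beyond the scatter) concern which group occupies the ring position, not where it is, so they bear only loosely on this change. Given that compound 3 already sits at the limit, compound 4 is expected to stay near it. Compound 4 is estimated at 190 ug/mL, within 110 ug/mL to 250 ug/mL. The expected step is an at least 1.0-fold lower number from compound 3 to compound 4 (0.02 log units; that floor lies within the scatter), a size that lies within the scatter.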

Compound 4, half-maximal inhibitory concentration: 84 ug/mL
Compound 4: the middle estimate sits 2.3-fold (0.35 log units) above what was measured, outside the stated range (below it).
By their numbers in this assay, from the lowest: compounds 2 and 4 (each within the scatter of the next); then compound 1. At a limit, above all of these: compound 3.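

In this assay, compounds 3 and 4 have the same atoms and differ only in where the nitro group sits, and that change alone gives an at least 2.3-fold lower number from compound 3 to compound 4 (0.37 log units; beyond the scatter), so the place of the group counts as well as its identity. Compound 3 has only a limit of the assay and no exact number, so this step is a floor and its true size is unknown: the limit of > 200 ug/mL in this assay, at which 1 of the 4 values shown sits.

With 4-nitrophenyl in place, the change from the plain phenyl of the first compound is a 2.1-fold lower number from compound 1 to compound 4 (0.33 log units; beyond the scatter), and the swap from 2-chlorophenyl gives no change at the digits printed from compound 2 to compound 4 (within the scatter), so a nitro group does not by itself hold the number at the limit.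

Going by these compounds, it remains open whether a chloro group moved in the same way would shift the number as the nitro group does. On these data alone, it is also open how an amine or a carboxylic acid at that place would read in this assay.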